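Cyclic Amine in Place of an Aminohydroxypropyl Thioether

This account rests on a few compounds, and the source may have more. Where it says the series, first, only, none or still open, it means among the compounds named here.

Compound 1, `CC(C)c1n[nH]c2c(NCc3ccc(-c4ccccn4)cc3)nc(SCCC(N)=O)nc12`: 120 nM
Compound 2, `CC(C)c1n[nH]c2c(NCc3ccc(-c4ccccn4)cc3)nc(SCC(N)=O)nc12`: 192 nM
Compound 3, `CC(C)c1n[nH]c2c(NCc3ccc(-c4ccccn4)cc3)nc(SC[C@H](O)CN)nc12`: 63 nM

In a functional assay on HT cells (Homo sapiens) for antiproliferative activity, read by fluorescence, with a stated time of 72 h (a lower number here means a stronger inhibitor of growth, a higher number a weaker inhibitor of growth), compound 3 has the lowest of the three numbers, yet the step of a 1.9-fold lower number from compound 1 to compound 3 (0.28 log units; within the scatter) is within the scatter, and only a 3.0-fold lower number from compound 2 to compound 3 (0.48 log units; beyond the scatter) is beyond it. Compound 4, `CC(C)c1n[nH]c2c(NCc3ccc(-c4ccccn4)cc3)nc(SC3CCCCC3N)nc12`, differs from compound 3 by 2-aminocyclohexyl in place of 3-amino-2-hydroxypropyl on a sulfur. The steps of a 1.9-fold lower number from compound 1 to compound 3 (0.28 log units; within the scatter) and a 3.0-fold lower number from compound 2 to compound 3 (0.48 log units; beyond the scatter) are the only ones bearing on it, since both vary the group on the sulfur; none removes the hydroxyl or closes a ring, so they guide weakly. With an amine kept on the chain, no step beyond the scatter is expected, and the estimated step is a 1.4-fold higher number from compound 3 to compound 4 (0.15 log units; within the scatter). Compound 4 is therefore expected at 90 nM, between 35 nM and 250 nM.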

Compound 4, concentration for 50% growth inhibition: 139 nM
For compound 4 the middle estimate is 1.5-fold (0.19 log units) below the measured one; the range from low to high includes it.
By their numbers in this assay, from the lowest: compounds 3, 1, 4 and 2 (each within the scatter of the next, the first and the last beyond it).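

Setting 2-aminocyclohexyl in place of 3-amino-2-hydroxypropyl on the sulfur removes the hydroxyl and adds a ring, and in this assay this gives a 2.2-fold higher number from compound 3 to compound 4 (0.34 log units; beyond the scatter), so this position does respond to that change. Compound 4 is not separated from the two amides, with a 1.4-fold lower number from compound 2 to compound 4 (0.14 log units; within the scatter) and a 1.2-fold higher number from compound 1 to compound 4 (0.06 log units; within the scatter). No evidence is at hand to explain these results.

On these data alone, whether the ring or the lost hydroxyl matters remains open, and a 3-aminopropyl chain on the sulfur would help separate them. As far as these compounds go, how the individual stereoisomers of 2-aminocyclohexyl compare also remains open.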